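The source may report more compounds than this note shows. Statements on the series, on what has been measured and on what is new or still open speak of the compounds shown alone.

Three compounds built on one shared core have so far been run in an ADME assay for permeability, using PAMPA, with a stated time of 30 min, at pH 7.4; on this read-out lower numbers stand for lower permeability and higher numbers for higher permeability. Compound 1 `COc1ccccc1Oc1ccc2c(NCCCNCc3ccco3)ccnc2c1` gives 317 10^-6 cm/s in this assay. Compound 2 `c1ccc(Oc2ccc3c(NCCCNCc4ccco4)ccnc3c2)cc1` gives 317 10^-6 cm/s; here no change at the digits printed from compound 1 to compound 2 (within the scatter). Compound 3 `COc1ccc(Oc2ccc3c(NCCCNCc4ccco4)ccnc3c2)cc1` gives 317 10^-6 cm/s and stands level with compounds 1 and 2 at the digits shown, with compound 1 its nearest and compound 2 its furthest neighbour, though neither gap is beyond the scatter. In this assay there is no change at the digits printed from compound 1 to compound 3 (within the scatter), and likewise no change at the digits printed from compound 2 to compound 3 (within the scatter).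

Compound 4 `c1ccc(Cc2ccc3c(NCCCNCc4ccco4)ccnc3c2)cc1` has not yet been measured. It differs from compound 3 by benzyl in place of 4-methoxyphenoxy on an aromatic carbon. Going by the values given here, no measured step touches anything but a methoxy group: hydrogen in place of methoxy on an aromatic carbon, methoxy in place of hydrogen on an aromatic carbon, or 4-methoxyphenyl in place of 2-methoxyphenyl on an oxygen on an aromatic ring, and each of them left the read-out unchanged within the scatter. The change to compound 4 is larger than any of these, so it is covered only in part, yet nothing measured points in either direction. The expected step is therefore no change at the digits printed from compound 3 to compound 4 (within the scatter), none beyond the scatter. Compound 4 is estimated at 317 10^-6 cm/s in this assay, within a range from 180 10^-6 cm/s to 450 10^-6 cm/s.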

Compound 4, apparent permeability: 23 10^-6 cm/s
Beside the measured number, compound 4's estimate is 14-fold (1.14 log units) above it; the whole stated range lies above it.
By their numbers in this assay, from the lowest: compound 4; then compounds 1, 2 and 3 (each within the scatter of the next).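

In this assay, going by these compounds alone, the earlier compounds showed only that methoxy could be removed or moved on the phenoxy group with no step beyond the scatter, whereas this position on an aromatic carbon of the shared core proves far from indifferent to the group it carries: benzyl in place of phenoxy gives a 14-fold lower number from compound 2 to compound 4 (1.14 log units; beyond the scatter), a change that keeps the carbon-only aromatic ring and swaps the oxygen link for a carbon link. The same exchange gives a 14-fold lower number from compound 3 to compound 4 (1.14 log units; beyond the scatter) and a 14-fold lower number from compound 1 to compound 4 (1.14 log units; beyond the scatter), so across these three compounds the drop appears whether methoxy is absent or sits at either of the two places tried. Nothing available here accounts for the size of this drop.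

The compounds shown leave open whether the low number belongs to the carbon link itself or to benzyl as a whole, and an amine link or a sulfur link at this position would help to separate the two. They also leave open whether methoxy on the benzyl ring would again leave the number unmoved, as it did on the phenoxy group.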